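The source may report more compounds than this note shows. Statements on the series, on what has been measured and on what is new or still open speak of the compounds shown alone.

Measured compounds:

Compound 1, `COc1cccc(Nc2nc3c(c(Oc4cccc(NC(=O)C=C(C)C)c4)n2)CSCC3)c1`: in a functional assay on A549 cells (Homo sapiens) for antiproliferative activity, read by MTT assay, with a stated time of 72 h (on this read-out lower numbers stand for stronger inhibition and higher numbers for weaker inhibition), compound 1 gives 19800 nM.
Compound 2, `COc1cccc(Nc2nc3c(c(Oc4cccc(NC(=O)/C=C/C(C)C)c4)n2)CSCC3)c1`: in this assay compound 2 gives 25300 nM.
Compound 3, `CC(C)=CC(=O)Nc1cccc(Oc2nc(Nc3cccc(C#N)c3)nc3c2CSCC3)c1`: in this assay compound 3 gives 36900 nM.

Compound 4, `CC(C)/C=C/C(=O)Nc1cccc(Oc2nc(Nc3cccc(C#N)c3)nc3c2CSCC3)c1`, has not yet been measured. It arises from compound 3 by one change: 3-methylbut-1-en-1-yl in place of 2-methylprop-1-en-1-yl on a carbonyl carbon. Exactly the same change, at the same place, has already been made once, from compound 1 to compound 2: 3-methylbut-1-en-1-yl in place of 2-methylprop-1-en-1-yl on a carbonyl carbon. That step gave a 1.3-fold higher number from compound 1 to compound 2 (0.11 log units; within the scatter), which is no more than the usual scatter of the assay. Compound 3 differs from compound 1 in its core, on a different ring: cyano in place of methoxy on an aromatic carbon, and that step gave a 1.9-fold higher number from compound 1 to compound 3 (0.27 log units; within the scatter), also within the scatter. All three measured numbers thus sit close together, and none can be called stronger or weaker than another.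

Because the earlier pairing gave a 1.3-fold higher number from compound 1 to compound 2 (0.11 log units; within the scatter), the step from compound 3 to compound 4 is expected to be of similar small size, a 1.2-fold higher number from compound 3 to compound 4 (0.10 log units; within the scatter), though the different core of compound 3 leaves room for the result to differ. Compound 4 is therefore estimated to give about 46000 nM in this assay, most likely between 22000 nM and 95000 nM.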

Compound 4, half-maximal inhibitory concentration: 35900 nM
Compound 4: middle estimate off by 1.3-fold (0.11 log units), on the high side; the measured number falls inside the stated range.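

In this assay, for the compounds shown here, putting 3-methylbut-1-en-1-yl in place of 2-methylprop-1-en-1-yl on the carbonyl carbon gives a 1.0-fold lower number from compound 3 to compound 4 (0.01 log units; within the scatter), and this step matches its earlier counterpart on the other core: the same change on two cores in this assay, a 1.3-fold higher number (0.11 log units; within the scatter) from compound 1 to compound 2 and a 1.0-fold lower number (0.01 log units; within the scatter) from compound 3 to compound 4, 1.3-fold (0.12 log units) apart, within the scatter of two such steps Cyano in place of methoxy gives a 1.4-fold higher number from compound 2 to compound 4 (0.15 log units; within the scatter), and this step also matches its earlier counterpart: the same change on two cores in this assay, a 1.9-fold higher number (0.27 log units; within the scatter) from compound 1 to compound 3 and a 1.4-fold higher number (0.15 log units; within the scatter) from compound 2 to compound 4, 1.3-fold (0.12 log units) apart, within the scatter of two such steps Each change therefore leaves the number within the scatter on both cores, but this does not show that a change with a clear effect would carry over from one core to the other, as no step here is large enough to test that.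

On these data alone, it remains open whether a longer chain on the carbonyl carbon, or an amine at the end of that chain, would move the number beyond the scatter. The same question stands for a carboxylic acid or a chlorine atom in the place held by cyano and methoxy.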